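Swapping the aryl group on a cytotoxicity core

The source may hold more compounds than are shown below. What is called first, only, known or untested is meant among the compounds shown, and "the series" means these compounds.

Compound 1 `COc1ccc(C2C(C#N)=C(N)N(c3cc(OC)c(OC)c(OC)c3)C3=C2C(=O)CC(C)(C)C3)cc1` and compound 2 `COc1cc(N2C(N)=C(C#N)C(c3c(O)ccc4ccccc34)C3=C2CC(C)(C)CC3=O)cc(OC)c1OC` share one core and differ only in the group on a saturated ring carbon. In a functional assay on Ehrlich cells (Mus musculus) for cytotoxicity, tested at 50 ug/mL (a higher number here means a stronger effect of the compound at the concentration tested, a lower number a weaker effect), compound 1 gives 11%, and in this assay compound 2 gives 15%. Among the compounds with values here, of the two numbers, the one for compound 2 is the larger, yet the gap to compound 1 is within the scatter, so the two are not separated. Within the data shown here, compound 3 `COc1cc(N2C(N)=C(C#N)C(c3ccc(C)o3)C3=C2CC(C)(C)CC3=O)cc(OC)c1OC` carries a change at that same saturated ring carbon: 5-methylfuran-2-yl in place of 2-hydroxynaphthalen-1-yl on a saturated ring carbon The only measured step that bears on this is a number 4 percentage points higher from compound 1 to compound 2 (within the scatter), also an exchange of the group on a saturated ring carbon, and it stayed within the scatter. No step beyond the scatter is therefore expected in this assay, and the expected change is a number 2 percentage points lower from compound 2 to compound 3 (within the scatter). Compound 3 is estimated at 13%, with a range from 3% to 25%.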

Compound 3, a percentage reported as activity, at one concentration (the size of the read-out at that concentration, not a potency): 41%
For compound 3 the middle estimate is 28 percentage points below the measured one; the measured number lies above the stated range.
By their numbers in this assay, from the lowest: compounds 1 and 2 (each within the scatter of the next); then compound 3.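

The group on this saturated ring carbon can clearly move the read-out in this assay: with 5-methylfuran-2-yl the result is a number 26 percentage points higher from compound 2 to compound 3 (beyond the scatter) and a number 30 percentage points higher from compound 1 to compound 3 (beyond the scatter), whereas the earlier exchange gave only a number 4 percentage points higher from compound 1 to compound 2 (within the scatter). In the step from compound 2, several things change at once: two six-membered aromatic rings of carbon only give way to one five-membered aromatic ring with 1 hetero atom, the heavy-atom count falls, and the hydrogen-bond donor is lost, so this pair cannot show which of these matters. No measurement available here explains the rise.

The compounds shown leave open whether the furan ring or its methyl group carries the effect. A plain furan-2-yl, a 5-methylthiophen-2-yl with sulfur in place of the ring oxygen, or an open n-butyl chain at this carbon would help separate these possibilities.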